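Nitro for methyl: compound 1 to compound 4

The source may report more compounds than this note shows. Statements on the series, on what has been measured and on what is new or still open speak of the compounds shown alone.

In an ADME assay on Vero cells (Chlorocebus sabaeus) for cytotoxicity, read by crystal violet staining (a lower number here means that less compound is tolerated, a higher number that more compound is tolerated), compound 1 (`Cc1ccc(/N=N/c2ccc(NCCCN(C)C)cc2)cc1`) gives 50000 nM and holds the second of the three measured numbers. Compound 3 (`O=C1CCN(/N=N/c2ccccc2)CC1`) gives 60000 nM and lies within the scatter of compound 1. Compound 2 (`CN(C)CCCN(/N=N/c1ccccc1)c1cccc(C(F)(F)F)c1`) gives 20000 nM and holds the lowest number, beyond the scatter of compound 1.

The next entry is compound 4 (`CN(C)CCCNc1ccc(/N=N/c2ccc([N+](=O)[O-])cc2)cc1`), which has no number yet in this assay and differs from compound 1 in one place: nitro in place of methyl on an aromatic carbon, para to a large group (nitro in place of methyl on an aromatic carbon). Going by the values given here, no two measured compounds differ in only one place, so the series holds no direct precedent for this change. Among the compounds with values here, the only guide is the narrow spread of the measured numbers, from compound 2 at 20000 nM to compound 3 at 60000 nM in structures that differ widely. A small downward step is expected, probably within the scatter, and the estimated step is a 1.7-fold lower number from compound 1 to compound 4 (0.22 log units; within the scatter) in this assay on this reading. Compound 4 is expected at 30000 nM (estimated range 10000 nM to 70000 nM).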

Compound 4, half-maximal cytotoxic concentration: 60000 nM
Estimate against measurement, compound 4: 2.0-fold (0.30 log units) below; the range from low to high includes it.
By their numbers in this assay, from the lowest: compound 2; then compounds 1, 3 and 4 (each within the scatter of the next).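

Nitro in place of methyl on an aromatic carbon, para to a large group, gives a 1.2-fold higher number from compound 1 to compound 4 (0.08 log units; within the scatter) in this assay, the first one-place comparison in the series. At this position, a group with hydrogen-bond acceptors can thus replace one without them, and the larger group leaves the reading within the scatter of compound 1, though this rests on a single pair on one core. Nothing on record explains why the reading stays within the scatter, and the data give no measured property of either group that bears on it.

On these data alone, whether the same holds for other groups at this position, such as a carboxylic acid, a nitrile or a primary amine, remains open, since one pair cannot show how far the position tolerates change. Going by these compounds alone, also open is whether the step from methyl to nitro would read the same on a core carrying a longer chain in place of the one in compound 1, or on a core with any other second change.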